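Side-chain swap on the compound 1 scaffold: expected step

This account rests on a few compounds, and the source may have more. Where it says the series, first, only, none or still open, it means among the compounds named here.

compound 1 `Cn1ncc(Cl)c1-c1cc(C(=O)N[C@@H]2CN[C@H](CC(O)CO)C[C@H]2c2ccc(F)c(F)c2)oc1Cl`: 690 nM
compound 2 `Cn1ncc(Cl)c1-c1cc(C(=O)N[C@@H]2CN[C@H](CC(O)CO)C[C@H]2c2ccc(Cl)c(Cl)c2)oc1Cl`: 1610 nM
compound 3 `Cn1ncc(Cl)c1-c1cc(C(=O)N[C@@H]2CN[C@H](CCN3CCCCC3)C[C@H]2c2ccc(Cl)c(Cl)c2)oc1Cl`: 1660 nM

In a functional assay on OVCAR-8 cells (Homo sapiens) for antiproliferative activity (a lower number here means a stronger inhibitor, a higher number a weaker inhibitor), compound 1 has the lowest number of the three at 690 nM, and its gaps to compound 2 and compound 3 both lie beyond the scatter. Compound 4 `CNC(=O)C[C@@H]1C[C@@H](c2ccc(F)c(F)c2)[C@H](NC(=O)c2cc(-c3c(Cl)cnn3C)c(Cl)o2)CN1` keeps the core of compound 1 and differs only in the side chain: methylcarbamoyl in place of 1,2-dihydroxyethyl on a saturated chain carbon bound to a saturated ring carbon. Within the data shown here, the one measured step at this place is a 1.0-fold higher number from compound 2 to compound 3 (0.01 log units; within the scatter). Among the measured compounds shown here, it involves different groups and comes from compound 2, so it is only indirect evidence, and no measured step shows the effect of methylcarbamoyl itself. The other measured step, a 2.3-fold higher number from compound 1 to compound 2 (0.37 log units; beyond the scatter), concerns the substituted phenyl group, which is the same in compound 1 and compound 4, so it does not apply here. No shift beyond the scatter is therefore expected, and the expected step is a 1.1-fold higher number from compound 1 to compound 4 (0.04 log units; within the scatter). Compound 4 is expected at 760 nM, with an estimated range of 330 nM to 1800 nM.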

Compound 4, half-maximal inhibitory concentration: 800 nM
Compound 4: the middle estimate sits 1.1-fold (0.02 log units) below what was measured, within the range that was stated.
By their numbers in this assay, from the lowest: compounds 1, 4, 2 and 3 (each within the scatter of the next, the first and the last beyond it).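

In this assay, the step at this place on the 3,4-difluorophenyl background is a 1.2-fold higher number from compound 1 to compound 4 (0.06 log units; within the scatter), so methylcarbamoyl can stand in place of 1,2-dihydroxyethyl without a shift beyond the scatter, even though the hydrogen-bond donor and acceptor counts both fall and a nitrogen enters. Until now the only reading at this place was a 1.0-fold higher number from compound 2 to compound 3 (0.01 log units; within the scatter), on the 3,4-dichlorophenyl background and with a different entering group; both listed steps at this place now lie within the scatter, and neither goes against that pattern. The compounds shown offer no measured basis for explaining this flat response.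

Still open, going by these compounds, is whether a carboxylic acid, a primary amine or a longer chain at this place would move the number beyond the scatter. Also open, on these data alone, is whether methylcarbamoyl gives the same small step with 3,4-dichlorophenyl in place of 3,4-difluorophenyl.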